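The compounds below may be only part of what the source reports. "The series", "measured", "known", "first", "only" and "open" are said of these compounds alone.

Working notes on the series. Two compounds have numbers in a functional assay on Jurkat cells for inhibition of nuclear factor NF-kappa-B complex (Homo sapiens); a higher number here means a weaker inhibitor, a lower number a stronger inhibitor. Compound 1 `CCOC(=O)c1cnc(-c2ccccc2)nc1NN1C(=O)C=C(C)C1=O` gives in this assay 100 nM. Compound 2 `CCOC(=O)c1cnc(C(=O)c2ccco2)nc1NN1C(=O)C=C(C)C1=O` gives in this assay 700 nM. Compound 2 thus stands highest of the two numbers, its nearest neighbour being compound 1, and the step of a 7.0-fold higher number from compound 1 to compound 2 (0.85 log units; beyond the scatter). Compound 3 `CCOC(=O)c1cnc(C2CC2)nc1NN1C(=O)C=C(C)C1=O` has not yet been measured in this assay. It differs from compound 2 by cyclopropyl in place of (furan-2-yl)carbonyl on an aromatic carbon. Going by the values given here, no measured step in this assay bears directly on this change: the only step known, a 7.0-fold higher number from compound 1 to compound 2 (0.85 log units; beyond the scatter), swaps one aromatic group for another carbonyl-linked aromatic group, and neither side of it carries a cyclopropyl. The direction of the step to compound 3 in this assay is therefore open, and any expectation is wide. Compound 3 is estimated at 400 nM, within 80 nM to 3000 nM, which would mean an expected step of a 1.8-fold lower number from compound 2 to compound 3 (0.24 log units; within the scatter).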

Compound 3, half-maximal inhibitory concentration: 1000 nM
For compound 3 the middle estimate is 2.5-fold (0.40 log units) below the measured one; the range from low to high includes it.
By their numbers in this assay, from the lowest: compound 1; then compounds 2 and 3 (each within the scatter of the next).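

At this position, on an aromatic carbon between two ring nitrogen atoms, cyclopropyl and (furan-2-yl)carbonyl cannot be told apart in this assay (here a 1.4-fold higher number from compound 2 to compound 3 (0.15 log units; within the scatter)), although the two groups share neither a ring type nor a carbonyl. The change from phenyl to cyclopropyl gives a clear loss (here a 10-fold higher number from compound 1 to compound 3 (1.00 log units; beyond the scatter)), so among the three groups phenyl alone stands apart, with compound 1 beyond the scatter from both compound 2 and compound 3. No measurement at hand accounts for this separation of phenyl from the other two groups.

Going by these compounds alone, whether phenyl is favoured for its directly attached aromatic ring remains open, since only one such group appears here. An amine or a longer alkyl chain at this position could fall with phenyl or with the other two groups, and the compounds shown do not say which.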